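A Chlorophenyl Swap Tested on a Second Core

The compounds below may be only part of what the source reports. "The series", "measured", "known", "first", "only" and "open" are said of these compounds alone.

Compound 3 `CCCCCc1ccc(C#Cc2c(-c3ccc(CCCCC)cc3)oc3nc(=O)n(Cc4cn(Cc5ccccc5)nn4)cc23)cc1` and compound 1 `CCCCCc1ccc(C#Cc2c(-c3ccc(CCCCC)cc3)oc3nc(=O)n(Cc4cn(-c5ccc(Cl)cc5)nn4)cc23)cc1` share a core and differ in a single group. In a functional assay on HeLa cells (Homo sapiens) for antiproliferative activity, read by MTT assay, with a stated time of 72 h (a higher number here means a weaker inhibitor, a lower number a stronger inhibitor), compound 3 gives 73000 nM. For compound 1 the result is a limit of the assay, > 100000 nM. The change between them, (4-chlorophenyl in place of benzyl on an aromatic nitrogen), produced an at least 1.3-fold higher number from compound 3 to compound 1 (0.13 log units; that floor lies within the scatter), and because the limit of > 100000 nM in this assay, at which 1 of the 3 values shown sits, the true size of that step is not known. Compound 2 `O=c1nc2oc(C3CC3)c(C#CC3CC3)c2cn1Cc1cn(Cc2ccccc2)nn1` carries a different core, and the difference between the two cores is not broken down here. In this assay compound 2 gives 6510 nM, the lowest number among the measured compounds and well below compound 3. Compound 4 `O=c1nc2oc(C3CC3)c(C#CC3CC3)c2cn1Cc1cn(-c2ccc(Cl)cc2)nn1` is not yet measured; it stands to compound 2 as compound 1 stands to compound 3, through the same change, (4-chlorophenyl in place of benzyl on an aromatic nitrogen). For compound 4 the expected step is a 1.8-fold higher number from compound 2 to compound 4 (0.27 log units; within the scatter), a weakening in line with the measured pair, though that pair rests on one comparison whose second member is only a limit. Compound 4 is therefore estimated at 12000 nM, between 5000 nM and 40000 nM.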

Compound 4, half-maximal inhibitory concentration: 16100 nM
Compound 4: the middle estimate sits 1.3-fold (0.13 log units) below what was measured; the range from low to high includes it.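

In this assay, putting 4-chlorophenyl in place of benzyl on the aromatic nitrogen of the second core gives a 2.5-fold higher number from compound 2 to compound 4 (0.39 log units; beyond the scatter), a modest weakening. Both cores move in the same direction, but whether the change has the same size on each remains unsettled: the same change on two cores in this assay, an at least 1.3-fold higher number (0.13 log units; that floor lies within the scatter) from compound 3 to compound 1 and a 2.5-fold higher number (0.39 log units; beyond the scatter) from compound 2 to compound 4; the limit leaves it open whether they differ

For compound 1, the value of > 100000 nM is a limit of the assay, so the first step is known only as a floor, and two cores do not establish a constant step across the series.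

The compounds shown leave open whether the higher number goes with the chlorine or with the change from benzyl to a ring set directly on the nitrogen, since the swap alters both at once, and plain phenyl and 4-chlorobenzyl would separate the two. They also leave open how the same position responds to an amine or a carboxylic acid on that ring, or to a longer chain in its place.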